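Pyridinyl for nitrophenyl on the alkenyl chain

This account rests on a few compounds, and the source may have more. Where it says the series, first, only, none or still open, it means among the compounds named here.

Working notes on the shared core. Compound 1 `O=[N+]([O-])c1cccc(/C=C/C[C@H]2C[C@@H]([C@@H](O)c3ccccc3)CO[C@@H]2c2ccccc2)c1` in a functional assay on HeLa cells (Homo sapiens) for cytotoxicity, read by WST assay, with a stated time of 48 h (on this read-out higher numbers stand for weaker inhibition and lower numbers for stronger inhibition), gives 7850 nM. Compound 2 `COc1ccc(/C=C/C[C@H]2C[C@@H]([C@@H](OC)c3ccc(OC)c(OC)c3)CO[C@@H]2c2ccc(OC)c(OC)c2)cc1OC` in this assay gives only a limit of the assay, > 100000 nM. For the measured compounds named here, compound 1 thus holds the only number measured outright; the other value, (the limit of > 100000 nM in this assay, at which 1 of the 2 values shown sits), is a limit and not a number. Going by the values given here, no step between measured compounds that differ in one place is available, so no measured step guides the next change.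

Compound 3 `O[C@@H](c1ccccc1)[C@H]1CO[C@H](c2ccccc2)[C@@H](C/C=C/c2ccncc2)C1` is the unmeasured analogue of compound 1. It differs by pyridin-4-yl in place of 3-nitrophenyl on a double-bonded chain carbon bound to a double-bonded chain carbon. Among the compounds with values here, with no measured step of this kind to lean on, the step of a 1.5-fold higher number from compound 1 to compound 3 (0.18 log units; within the scatter) is expected to be small, a modest weakening at most and possibly none beyond the scatter. Compound 3 is therefore expected to give 12000 nM in this assay, within a range of 3000 nM to 50000 nM.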

Compound 3, half-maximal inhibitory concentration: > 100000 nM
Compound 3 ended at the assay's limit; the forecaster's own chance of this, stated with the estimate: 12%; middle value at least 8.3-fold (0.92 log units) from the limit.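

In this assay, for the compounds shown here, pyridin-4-yl in place of 3-nitrophenyl on a double-bonded chain carbon bound to a double-bonded chain carbon gives the first measured step, an at least 12-fold higher number from compound 1 to compound 3 (1.10 log units; beyond the scatter). The value of compound 3, > 100000 nM, is a limit and not a number, so the step has a lower bound but no exact size. This position is therefore not indifferent to the aromatic group it carries, and among the compounds shown, a measurable value remains confined to compound 1: the limit of > 100000 nM in this assay, at which 2 of the 3 values shown sit.

The compounds shown do not separate the loss of the nitro group from the entry of the ring nitrogen. A plain phenyl or an aminophenyl group on the same chain carbon would address that question.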